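Changing the Aryl Ether Head Group of Compound 3

The compounds below may be only part of what the source reports. "The series", "measured", "known", "first", "only" and "open" are said of these compounds alone.

Measured so far:
compound 1 `COc1cc(C(C)=O)ccc1OCCCN1CCC(C(c2ccc(F)cc2)c2ccc(F)c(F)c2)CC1` gives 1.26 nM in a functional assay (aorta) with Oryctolagus cuniculus as the target; on this read-out lower numbers stand for tighter binding and higher numbers for weaker binding
compound 2 `COc1cc(C(C)=O)ccc1OCCCN1CCC(C(c2ccc(C)cc2)c2ccc(C)cc2)CC1` gives 15.9 nM in this assay
compound 3 `COc1cc(C(C)O)ccc1OCCCN1CCC(C(c2ccc(F)cc2)c2ccc(F)cc2)CC1` gives 10 nM in this assay

Compound 3 holds the second highest of these three numbers. Its nearest neighbour is compound 2, whose number lies within the scatter of compound 3, so the two cannot be ordered. Compound 1 gives a lower number beyond the scatter.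

Compound 4 `CC(=O)Nc1ccc(OCCCN2CCC(C(c3ccc(F)cc3)c3ccc(F)cc3)CC2)cc1` differs from compound 3 in one place: 4-acetamidophenyl in place of 4-(1-hydroxyethyl)-2-methoxyphenyl on an oxygen on a saturated carbon. Among the measured compounds shown here, no measured pair shows this change, so its effect is unknown. The expected step from compound 3 to compound 4 in this assay is a small loss, a 2.0-fold higher number from compound 3 to compound 4 (0.30 log units; within the scatter). Compound 4 is estimated to give 20 nM in this assay, with a range from 5 nM to 80 nM.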

Compound 4, dissociation constant: 12.6 nM
Beside the measured number, compound 4's estimate is 1.6-fold (0.20 log units) above it; the measured number falls inside the stated range.
By their numbers in this assay, from the lowest: compound 1; then compounds 3, 4 and 2 (each within the scatter of the next).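

Putting 4-acetamidophenyl in place of 4-(1-hydroxyethyl)-2-methoxyphenyl on this oxygen gives a 1.3-fold higher number from compound 3 to compound 4 (0.10 log units; within the scatter) in this assay and leaves the two compounds impossible to order. This position can therefore carry a head group with a nitrogen and a double bond outside the ring and no methoxy, with no difference the read-out can separate from scatter. Nothing at hand explains why these two groups read alike. Still open, as far as these compounds go, is whether a head group carrying an amine or a carboxylic acid would read the same, and whether 4-acetamidophenyl would hold up on the core of compound 1.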